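This account rests on a few compounds, and the source may have more. Where it says the series, first, only, none or still open, it means among the compounds named here.

Measured compounds:
compound 1 `C=C1C[C@]23C[C@@]1(O)CC[C@@H]2c1cccc(C)c1[C@@H]3Cn1cc(-c2ccc(Br)cc2)nn1`: > 20000 nM
compound 2 `C=C1C[C@]23C[C@@]1(O)CC[C@H]2c1cc(Br)c(O)c(C)c1[C@@H]3Cn1cc(-c2ccc(C)cc2)nn1`: > 20000 nM
compound 3 `Cc1c(O)ccc2c1[C@H](Cn1cc(-c3ccccc3)nn1)[C@@]13CC(=O)[C@@](C)(CC[C@@H]21)C3`: > 20000 nM

In a functional assay on HL-60 cells (Homo sapiens) for cytotoxicity, read by MTT assay, with a stated time of 4 days (a lower number here means a stronger inhibitor, a higher number a weaker inhibitor), compound 1 returns only a limit, > 20000 nM, not a number. Compound 2 also returns only a limit, > 20000 nM. Compound 3 returns a limit as well, > 20000 nM. Every value in hand therefore sits at the limit of > 20000 nM in this assay, at which 3 of the 3 values shown sit. Within the data shown here, compound 1 thus stands nowhere in particular: it is not separated from compound 2 or compound 3 by any number, and no step between measured compounds exists on which a trend could rest.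

Compound 4 `C=C1C[C@]23C[C@@]1(O)CC[C@@H]2c1cccc(C)c1[C@@H]3Cn1cc(-c2ccc(F)cc2)nn1` is not yet measured. It differs from compound 1 in one place: fluoro in place of bromo on an aromatic carbon. Among the measured compounds shown here, with no measured step in this assay to show what such a change does, and with all three measured values sitting at the limit, no step beyond the usual scatter is expected from compound 1 to compound 4; the estimated step that the limit leaves unreadable from compound 1 to compound 4 is set accordingly. Compound 4 is expected to give 30000 nM, between 8000 nM and 100000 nM, most likely reported again as a limit.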

Compound 4, half-maximal inhibitory concentration: > 20000 nM
Compound 4: no number, only a limit (the forecaster's own chance of this, stated with the estimate: 85%); the middle value does not contradict the limit.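

Compound 1 and compound 4 both return only limits, not numbers, in this assay, so fluoro in place of bromo gives no readable step: the limit of > 20000 nM in this assay, at which 4 of the 4 values shown sit. The compounds shown leave open which change to the shared core, if any, would give a measurable value in this assay.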